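This account rests on a few compounds, and the source may have more. Where it says the series, first, only, none or still open, it means among the compounds named here.

Measured in an ADME assay on HepG2 cells (Homo sapiens) for cytotoxicity, read by MTT assay, with a stated time of 48 h, tested at 10 uM; on this read-out lower numbers stand for a weaker effect and higher numbers for a stronger effect at the one concentration tested:
compound 1 `O=c1cc(-c2ccc(Cl)cc2)oc2cc(OCCCCCCCCN3CCCC3)ccc12` gives 25.7%
compound 2 `O=c1cc(-c2ccc(OCc3ccccc3)cc2)oc2cc(OCCCCCCCCN3CCCC3)ccc12` gives 54.3%
compound 3 `O=c1cc(-c2ccc(-c3ccccc3)cc2)oc2cc(OCCCCCCCCN3CCCC3)ccc12` gives 71.9%

Compound 3 stands highest of the three numbers, shown by a number 46.2 percentage points higher from compound 1 to compound 3 (beyond the scatter) and a number 17.6 percentage points higher from compound 2 to compound 3 (beyond the scatter), both beyond the scatter. Compound 4 `COc1ccccc1-c1cc(=O)c2ccc(OCCCCCCCCN3CCCC3)cc2o1` differs from compound 3 as follows: 2-methoxyphenyl in place of 4-phenylphenyl on an aromatic carbon.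

The measured steps bearing on this change are those that put a larger group in place of chloro, a number 28.6 percentage points higher from compound 1 to compound 2 (beyond the scatter) and a number 46.2 percentage points higher from compound 1 to compound 3 (beyond the scatter), and the step between the two larger groups, a number 17.6 percentage points higher from compound 2 to compound 3 (beyond the scatter). Compound 4 removes the 4-phenylphenyl that gives compound 3 its high number, so a downward step beyond the scatter in this assay is expected, though the change is not a plain reversal of any measured step. The estimate for compound 4 is 35% (range 15% to 60%), meaning an expected step of a number 36.9 percentage points lower from compound 3 to compound 4 (beyond the scatter).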

Compound 4, a percentage reported as inhibition, at one concentration (the size of the read-out at that concentration, not a potency): 24.3%
Beside the measured number, compound 4's estimate is 10.7 percentage points above it, within the range that was stated.
By their numbers in this assay, from the lowest: compounds 4 and 1 (each within the scatter of the next); then compound 2; then compound 3.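

In this assay, the step of a number 47.6 percentage points lower from compound 3 to compound 4 (beyond the scatter) shows that the high number at this position, next to the ring oxygen, does not survive the exchange of 4-phenylphenyl for the one-ring 2-methoxyphenyl. The step of a number 1.4 percentage points lower from compound 1 to compound 4 (within the scatter) leaves 2-methoxyphenyl and 4-chlorophenyl unseparated, so among these compounds the higher numbers stay with the benzyloxy and phenyl substituents of compound 2 and compound 3. No measurement here bears on the reason for either step.

Open, on these data alone, is how a 4-methoxyphenyl would read against compound 4. Also open, as far as these compounds go, is whether 4-phenylphenyl would keep its number with a shorter chain on the core.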